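The source may report more compounds than this note shows. Statements on the series, on what has been measured and on what is new or still open speak of the compounds shown alone.

Three compounds have been measured in a functional assay on HepG2 cells (Homo sapiens) for antiproliferative activity, read by MTT assay, with a stated time of 24 h; on this read-out lower numbers stand for stronger inhibition and higher numbers for weaker inhibition:

Compound 1 `c1ccc(C2=NN(c3ccc(-c4ccccc4)nn3)C(c3ccccc3)C2)cc1` gives 10000 nM.
Compound 2 `Clc1ccc(C2CC(c3ccccc3)=NN2c2ccc(-c3ccccc3)nn2)cc1` gives 6310 nM.
Compound 3 `Clc1ccc(C2=NN(c3ccc(-c4ccccc4)nn3)C(c3ccccc3)C2)cc1` gives 8750 nM.

Compound 3 has the second highest number of the three; its nearest neighbour is compound 1, and its values and those of compound 2 all sit within the usual scatter of one another, so no order among them can be claimed.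

Compound 4 `Clc1ccc(C2=NN(c3ccc(-c4ccccc4)nn3)C(c3ccc(Cl)cc3)C2)cc1` differs from compound 3 in one place: chloro in place of hydrogen on an aromatic carbon. Two measured steps are of the same kind, each adding a chloro group to an aromatic carbon: a 1.6-fold lower number from compound 1 to compound 2 (0.20 log units; within the scatter) and a 1.1-fold lower number from compound 1 to compound 3 (0.06 log units; within the scatter). Both are small and within the scatter, pointing if anywhere slightly downward. A second chloro group is therefore expected to make at most a small difference in this assay, estimated as a 1.3-fold lower number from compound 3 to compound 4 (0.10 log units; within the scatter).

Compound 4 is expected to give about 7000 nM, with a likely range from 3500 nM to 14000 nM.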

Compound 4, half-maximal inhibitory concentration: 10000 nM
Compound 4: the middle estimate sits 1.4-fold (0.15 log units) below what was measured; low and high end bracket the measured number.
By their numbers in this assay, from the lowest: compounds 2, 3, 1 and 4 (each within the scatter of the next).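

In this assay, a second chloro group, phenyl to 4-chlorophenyl, brings no readable change on either of the two phenyl groups: the steps are a 1.1-fold higher number from compound 3 to compound 4 (0.06 log units; within the scatter) and a 1.6-fold higher number from compound 2 to compound 4 (0.20 log units; within the scatter). On the first of these phenyl groups, the change reads alike whether or not the other already carries chloro: the same change on two cores in this assay, a 1.6-fold lower number (0.20 log units; within the scatter) from compound 1 to compound 2 and a 1.1-fold higher number (0.06 log units; within the scatter) from compound 3 to compound 4, 1.8-fold (0.26 log units) apart, within the scatter of two such steps The second phenyl group gives the same picture: the same change on two cores in this assay, a 1.1-fold lower number (0.06 log units; within the scatter) from compound 1 to compound 3 and a 1.6-fold higher number (0.20 log units; within the scatter) from compound 2 to compound 4, 1.8-fold (0.26 log units) apart, within the scatter of two such steps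

All four compounds carry only hydrogen or chloro at these two places, so the data show nothing about a different kind of group there. On these data alone, whether an amine, a carboxylic acid or a longer chain on either phenyl group would move the number beyond the scatter remains open.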